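From isopropyl to cyclohexylmethyl on an amine nitrogen

A few compounds are considered here, and "the series" means these few. Any claim that something is new, unique, unknown or untested is made for them only; others in the source may bear on it.

Measured in an ADME assay for permeability, using PAMPA, at pH 7.4 (a lower number here means that the compound crosses the layer more slowly, a higher number that the compound crosses the layer faster), so far
- compound 1 `c1cnc2c(c1)CCC[C@@H]2N(CC1CC1)C[C@H]1Cc2c(cccc2N2CCNCC2)CN1` gives 87 nm/s
- compound 2 `CCN(C[C@H]1Cc2c(cccc2N2CCNCC2)CN1)[C@H]1CCCc2cccnc21` gives 75 nm/s
- compound 3 `CC(C)N(C[C@H]1Cc2c(cccc2N2CCNCC2)CN1)[C@H]1CCCc2cccnc21` gives 16 nm/s

Compound 3 has the lowest number of the three, and its gaps to both others lie beyond the scatter. Compound 4 `c1cnc2c(c1)CCC[C@@H]2N(CC1CCCCC1)C[C@H]1Cc2c(cccc2N2CCNCC2)CN1` carries cyclohexylmethyl in place of isopropyl on an amine nitrogen and has not yet been measured. The closest guide is a 5.4-fold lower number from compound 1 to compound 3 (0.74 log units; beyond the scatter) when isopropyl replaces cyclopropylmethyl. A similar drop appears as a 4.7-fold lower number from compound 2 to compound 3 (0.67 log units; beyond the scatter) while a 1.2-fold lower number from compound 1 to compound 2 (0.06 log units; within the scatter) stays small. Within the data shown here, a rise of modest size is therefore expected in this assay on leaving isopropyl, although no measured compound carries cyclohexylmethyl. The expected change is a 4.4-fold higher number from compound 3 to compound 4 (0.64 log units; beyond the scatter) by this estimate. For compound 4 the estimated number is 70 nm/s with an expected range from 25 nm/s to 200 nm/s here.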

Compound 4, apparent permeability: 9 nm/s
Estimate against measurement, compound 4: 7.8-fold (0.89 log units) above; the whole stated range lies above it.
By their numbers in this assay, from the lowest: compounds 4 and 3 (each within the scatter of the next); then compounds 2 and 1 (each within the scatter of the next).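

In this assay, putting cyclohexylmethyl in place of isopropyl on this amine nitrogen changes little, with a 1.8-fold lower number from compound 3 to compound 4 (0.25 log units; within the scatter). A bulky group of this kind therefore sits with isopropyl rather than with the smaller groups, as an 8.3-fold lower number from compound 2 to compound 4 (0.92 log units; beyond the scatter) and a 9.7-fold lower number from compound 1 to compound 4 (0.99 log units; beyond the scatter) both show. Nothing measured here explains this result. The compounds shown leave open whether a longer straight chain, or a chain ending in an amine or a hydroxyl, on this nitrogen would fall with compound 1 and compound 2 or with compound 3 and compound 4.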